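Replacing 4-nitrophenyl with 4-iodophenyl

The source may report more compounds than this note shows. Statements on the series, on what has been measured and on what is new or still open speak of the compounds shown alone.

Compound 1 `Oc1ccc2ccccc2c1C(Nc1nc2ccccc2s1)c1cn(-c2ccccc2)nc1-c1ccccc1`: 36200 nM
Compound 2 `O=[N+]([O-])c1ccc(-c2nn(-c3ccccc3)cc2C(Nc2nc3ccccc3s2)c2c(O)ccc3ccccc23)cc1`: 41300 nM

In a functional assay on A549 cells (Homo sapiens) for antiproliferative activity, read by MTT assay, with a stated time of 48 h (a lower number here means a stronger inhibitor, a higher number a weaker inhibitor), compound 2 and compound 1 lie within the scatter of each other. Compound 3 `Oc1ccc2ccccc2c1C(Nc1nc2ccccc2s1)c1cn(-c2ccccc2)nc1-c1ccc(I)cc1` differs from compound 2 by iodo in place of nitro on an aromatic carbon, with iodo in place of nitro on an aromatic carbon. Among the compounds with values here, the one measured step bearing on this is a 1.1-fold higher number from compound 1 to compound 2 (0.06 log units; within the scatter), which put nitro in place of hydrogen on that same carbon. No shift beyond the scatter is therefore expected in this assay, in either direction. The estimated step is a 1.1-fold lower number from compound 2 to compound 3 (0.06 log units; within the scatter). Compound 3 is expected at 36000 nM, with an estimated range of 18000 nM to 70000 nM.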

Compound 3, half-maximal inhibitory concentration: 23100 nM
Beside the measured number, compound 3's estimate is 1.6-fold (0.19 log units) above it; low and high end bracket the measured number.
By their numbers in this assay, from the lowest: compounds 3, 1 and 2 (each within the scatter of the next).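

In this assay, iodo in place of nitro gives a 1.8-fold lower number from compound 2 to compound 3 (0.25 log units; within the scatter) and iodo in place of hydrogen gives a 1.6-fold lower number from compound 1 to compound 3 (0.20 log units; within the scatter) on the same aromatic carbon. With a third group now read at this carbon, hydrogen, nitro and iodo all lie within the scatter of one another, so neither the 4-nitrophenyl nor the 4-iodophenyl compound separates from the plain phenyl compound. Nothing available explains these small steps.

On these data alone, whether an amine or a carboxylic acid on this carbon would move the number beyond the scatter remains open. So does whether any group here can do so at all.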